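A few compounds are considered here, and "the series" means these few. Any claim that something is new, unique, unknown or untested is made for them only; others in the source may bear on it.

The measured compounds in a functional assay on HeLa cells (Homo sapiens) for cytotoxicity, read by cell counting, with a stated time of 4 days (a lower number here means a stronger inhibitor, a higher number a weaker inhibitor), are:
compound 1, `Nc1ccc(/C=C2\SC(=O)N(Cc3ccccc3)C2=O)cc1`, which gives 46000 nM;
compound 2, `C=C(Br)C(=O)Nc1ccc(/C=C2\SC(=O)N(Cc3ccccc3)C2=O)cc1`, which gives 1000 nM;
compound 3, `C=C(Br)C(=O)Nc1cccc(/C=C2\SC(=O)N(Cc3ccc(F)cc3)C2=O)c1`, which gives 800 nM.

Among these three, compound 2 has the second highest number. Its nearest neighbour is compound 3, whose number lies within the usual scatter of its own, and its furthest is compound 1. Going by the values given here, the only step between measured compounds that differ in one place runs from compound 1 to compound 2, and it is a 46-fold lower number from compound 1 to compound 2 (1.66 log units; beyond the scatter).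

Compound 4, `C=C(Br)C(=O)Nc1ccc(/C=C2\SC(=O)N(Cc3ccc(Cl)cc3)C2=O)cc1`, differs from compound 2 in one place: chloro in place of hydrogen on an aromatic carbon. Among the compounds with values here, no measured step touches the benzyl part of the shared core on its own. Within the data shown here, compound 3 differs from compound 2 in more than one place, so no single step is given for that pair; their two numbers show only that they lie within the usual scatter of each other. Among the measured compounds shown here, the one measured step, from compound 1 to compound 2, concerns a different part of the molecule and gives no guide to the size of this change. With nothing pointing either way, the step from compound 2 to compound 4 in this assay is expected to stay within the scatter, a 1.3-fold lower number from compound 2 to compound 4 (0.10 log units; within the scatter). Compound 4 is therefore estimated at 800 nM, with a range from 300 nM to 2500 nM.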

Compound 4, half-maximal inhibitory concentration: 2300 nM
For compound 4 the middle estimate is 2.9-fold (0.46 log units) below the measured one; the measured number falls inside the stated range.
By their numbers in this assay, from the lowest: compounds 3 and 2 (each within the scatter of the next); then compound 4; then compound 1.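

In this assay, going by these compounds alone, the change from benzyl to 4-chlorobenzyl gives a 2.3-fold higher number from compound 2 to compound 4 (0.36 log units; beyond the scatter) and is the first direct reading of this part of the molecule, as the earlier single step concerned only the group on the aromatic nitrogen. It shows that this position is not indifferent: one chlorine, placed para to a large group on the six-membered aromatic ring, moves the number in the weaker direction by more than the usual scatter. The shift is modest beside a 46-fold lower number from compound 1 to compound 2 (1.66 log units; beyond the scatter) and, with only one substituent compared against hydrogen here, nothing available accounts for the direction or size of this step.

The compounds shown leave open whether this weakening is particular to chloro or would also appear with a different group at the same carbon, such as methyl, methoxy or a carboxylic acid. They also leave open whether chloro would have the same effect at another carbon of that ring, or on a molecule that carries the free amine of compound 1 rather than the (1-bromoethenyl)carbonyl group.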